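The compounds below may be only part of what the source reports. "The series", "measured", "known", "first", "only" and "open" are said of these compounds alone.

Compound 1, `N=C(N)NCCCOc1ccc(CNc2nc3ccc(Oc4ccc(C(F)(F)F)cc4)cc3s2)cc1`, is the weaker of the two measured compounds: in an assay on SH-SY5Y cells for inhibition of Voltage-dependent N-type calcium channel subunit alpha-1B (Homo sapiens), read by FLIPR and calcium flux, with stated times of 600 s and 300 s, in the presence of a further agent that is not named here (a higher number here means a weaker inhibitor, a lower number a stronger inhibitor), compound 1 gives 167000 nM, the highest of the two numbers. Compound 2, `NCCCOc1ccc(CNc2nc3ccc(Oc4ccc(C(F)(F)F)cc4)cc3s2)cc1`, gives 59000 nM, and the step of a 2.8-fold lower number from compound 1 to compound 2 (0.45 log units; beyond the scatter) concerns only the amine end. Compound 3, `N=C(N)NCCCOc1ccc(CNc2nc3ccc(Oc4cccc(C(F)(F)F)c4)cc3s2)cc1`, differs from compound 1 in another place: 3-(trifluoromethyl)phenyl in place of 4-(trifluoromethyl)phenyl on an oxygen on an aromatic ring. Within the data shown here, no measured step touches the trifluoromethylphenyl, so nothing shows whether moving the trifluoromethyl matters, and a step within the scatter is expected, no change at the digits printed from compound 1 to compound 3 (within the scatter). Compound 3 is therefore estimated at 167000 nM, within 60000 nM to 450000 nM.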

Compound 3, half-maximal inhibitory concentration: 130000 nM
Compound 3: the middle estimate sits 1.3-fold (0.11 log units) above what was measured, within the range that was stated.
By their numbers in this assay, from the lowest: compound 2; then compounds 3 and 1 (each within the scatter of the next).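

In this assay, 3-(trifluoromethyl)phenyl in place of 4-(trifluoromethyl)phenyl on the oxygen gives a 1.3-fold lower number from compound 1 to compound 3 (0.11 log units; within the scatter), so compound 1 and compound 3 cannot be told apart. Among these compounds, this is the first reading of a change at this position, and for these two placements of the trifluoromethyl, the number does not separate them. No evidence is available to explain this result. Still open, going by these compounds, is whether a plain phenyl, or a nitrile in place of the trifluoromethyl, would give a different number. Also open, on these data alone, is whether 3-(trifluoromethyl)phenyl would match 4-(trifluoromethyl)phenyl in the amine series of compound 2.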